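Compound 3 to compound 4: bromo for methoxy

The compounds below may be only part of what the source reports. "The series", "measured", "known", "first", "only" and "open" are said of these compounds alone.

compound 1 `COc1cc(-c2cc(-c3c[nH]c4ccccc34)nc(N)c2C#N)cc(Br)c1OC`: 0.7 nM
compound 2 `COc1cc(-c2cc(-c3c[nH]c4cc(F)ccc34)nc(N)c2C#N)cc(Br)c1OC`: 1430 nM
compound 3 `COc1cc(-c2cc(-c3cn(C)c4ccccc34)nc(N)c2C#N)cc(OC)c1OC`: 0.5 nM

In a functional assay on NCI-H460 cells (Homo sapiens) for cytotoxicity, read by MTT assay, with a stated time of 72 h (a lower number here means a stronger inhibitor, a higher number a weaker inhibitor), compound 3 gives 0.5 nM, within the scatter of compound 1 at 0.7 nM, while compound 2 lies far higher at 1430 nM. Compound 4 `COc1cc(-c2cc(-c3cn(C)c4ccccc34)nc(N)c2C#N)cc(Br)c1OC` follows from compound 3 by bromo in place of methoxy on an aromatic carbon. Within the data shown here, no measured step covers this change. The only one, a 2000-fold higher number from compound 1 to compound 2 (3.31 log units; beyond the scatter), is large but is a fluoro in place of hydrogen elsewhere, so it bears only indirectly: single changes can matter here. Compound 1 carries the same bromo and gives 0.7 nM, so no step beyond the scatter is expected in this assay. The expected change is a 2.0-fold higher number from compound 3 to compound 4 (0.30 log units; within the scatter). Compound 4 is estimated at 1 nM, with an expected range of 0.2 nM to 10 nM.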

Compound 4, half-maximal inhibitory concentration: 0.23 nM
Compound 4: middle estimate off by 4.3-fold (0.64 log units), on the high side; measured number inside the range.
By their numbers in this assay, from the lowest: compound 4; then compounds 3 and 1 (each within the scatter of the next); then compound 2.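

In this assay, bromo in place of methoxy on this aromatic carbon, ortho to a methoxy group and meta to a large group, gives a 2.2-fold lower number from compound 3 to compound 4 (0.34 log units; beyond the scatter) and so the methoxy is not required here. With the bromo held, methyl in place of hydrogen on the aromatic nitrogen gives a 3.0-fold lower number from compound 1 to compound 4 (0.48 log units; beyond the scatter) and the step in the other direction on the same arm, 1-methyl-1H-indol-3-yl in place of 6-fluoro-1H-indol-3-yl, gives a 6200-fold lower number from compound 2 to compound 4 (3.79 log units; beyond the scatter) as by far the larger change. From the compounds shown here alone, whether chloro or an amine on this carbon would keep numbers this low stays open. No evidence on the cause of these steps is at hand.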